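This account rests on a few compounds, and the source may have more. Where it says the series, first, only, none or still open, it means among the compounds named here.

Compound 2 `O=C(Nc1ccc(F)cc1F)c1ccccc1OCc1ccc(F)cc1F` stands at the ceiling of an ADME assay on RAW264.7 cells (Mus musculus) for cytotoxicity, read by MTT assay, with a stated time of 24 h; on this read-out higher numbers stand for lower toxicity in this test and lower numbers for higher toxicity in this test: in this assay compound 2 gives > 40000 nM, which is a limit of the assay and not a number. Compound 1 `O=C(Nc1ccc(Cl)cc1F)c1ccccc1` likewise gives > 40000 nM, a limit. Compound 3 `COc1ccc(C(=O)Nc2ccc(F)cc2F)c(OCc2ccc(F)cc2F)c1` gives > 40000 nM, again a limit. Among the compounds with values here, the single step between measured compounds, a step that the two limits leave unreadable from compound 2 to compound 3, therefore cannot be sized; the whole of the evidence is the limit of > 40000 nM in this assay, at which 3 of the 3 values shown sit. Compound 4 `O=C(Nc1ccc(I)cc1F)c1ccccc1OCc1ccc(F)cc1F` differs from compound 2 by iodo in place of fluoro on an aromatic carbon. Within the data shown here, no measured step bears on this change, and three limits give no reading of its size or direction. The expected step is a number no higher from compound 2 to compound 4 (the limit leaves the size open), which is expected to leave compound 4 at the limit. Compound 4 is estimated at 40000 nM, within 15000 nM to 100000 nM.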

Compound 4, half-maximal cytotoxic concentration: 32600 nM
Compound 4: middle estimate off by 1.2-fold (0.09 log units), on the high side; low and high end bracket the measured number.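

Iodo in place of fluoro, on the aromatic carbon para to a large group, gives the first reading in this assay that is a number and not a limit. Going by these compounds, the change gives an at least 1.2-fold lower number from compound 2 to compound 4 (0.08 log units; that floor lies within the scatter) and its full size stays open, since compound 2 is held only by a limit. The step from compound 2 to compound 3 still cannot be read.

Open, on these data alone, is how a bromo, methyl or amine group at this position would read. Also open, as far as these compounds go, is whether iodo here would give a number on the methoxy-bearing core of compound 3.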